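The source may hold more compounds than are shown below. What is called first, only, known or untested is meant among the compounds shown, and "the series" means these compounds.

Of the compounds shown here, three of one series have been tested in a functional assay on MCF7 cells (Homo sapiens) for antiproliferative activity, read by MTT assay, with a stated time of 72 h (a lower number here means a stronger inhibitor, a higher number a weaker inhibitor), and a fourth awaits its result. Compound 1 `O=C1COc2ccc(-c3cccc(NS(=O)(=O)c4ccc(F)cc4)c3)cc2N1c1ccccc1` carries a phenyl on the amide-type nitrogen of its core. In this assay compound 1 gives only a limit, > 40000 nM. Compound 2 `O=C1COc2ccc(-c3cnc(Cl)c(NS(=O)(=O)c4ccc(F)cc4)c3)cc2N1c1ccccc1` has a different core; the difference between the two cores is not broken down here. In this assay compound 2 likewise gives only a limit, > 40000 nM. Compound 3 `O=C1COc2ccc(-c3cccc(NS(=O)(=O)c4ccc(F)cc4)c3)cc2N1C1CC1` differs from compound 1 by cyclopropyl in place of phenyl on an amide-type nitrogen in a ring. In this assay compound 3 also gives only a limit, > 40000 nM. The step that the two limits leave unreadable from compound 1 to compound 3 therefore cannot be read; both ends of it sit at the limit of > 40000 nM in this assay, at which 3 of the 3 values shown sit.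

Compound 4 `O=C1COc2ccc(-c3cnc(Cl)c(NS(=O)(=O)c4ccc(F)cc4)c3)cc2N1C1CC1` is the one not yet measured. It differs from compound 2 by cyclopropyl in place of phenyl on an amide-type nitrogen in a ring, the same change, at the same place, as that from compound 1 to compound 3. Since compound 1 gives > 40000 nM and compound 3 gives > 40000 nM, the change left no readable mark in this assay, and compound 2 starts from the same limit. It is therefore expected that the step that the limit leaves unreadable from compound 2 to compound 4 will again be unreadable, with compound 4 most likely reported as a limit as well. The estimate for compound 4 in this assay is 60000 nM, with a likely range from 20000 nM to 200000 nM.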

Compound 4, half-maximal inhibitory concentration: 16700 nM
Beside the measured number, compound 4's estimate is 3.6-fold (0.56 log units) above it; the whole stated range lies above it.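

In this assay, placing cyclopropyl instead of phenyl on the amide-type nitrogen of the core of compound 2 gives an at least 2.3-fold lower number from compound 2 to compound 4 (0.37 log units; beyond the scatter), so on this core the change has a readable result, and its true size may be larger since compound 2 gives only a limit. The same change on the core of compound 1 cannot be read, because both compounds of that pair stay at the limit of the assay, as do compound 2 and most of the series: the limit of > 40000 nM in this assay, at which 3 of the 4 values shown sit. The series therefore does not show that the change carries from one core to the other: a step of similar size could be hidden behind the limit on the core of compound 1, or there could be none at all, and a single readable pair establishes no general pattern.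

Still open, going by these compounds, is which feature separating the two cores matters, since the difference between them is not broken down here. Also open, on these data alone, is how this assay would respond on the core of compound 2 if the same amide-type nitrogen carried a methyl, an isopropyl or a longer chain ending in an amine instead of cyclopropyl.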